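Bromo for carboxy on an indazole benzylamine

The source may report more compounds than this note shows. Statements on the series, on what has been measured and on what is new or still open speak of the compounds shown alone.

Going by the values given here, compound 2 `O=C(O)c1cccc(CNc2cc(C(F)(F)F)cc3[nH]ncc23)c1` gives 1690 nM in an assay for inhibition of Tryptophan 2,3-dioxygenase (Homo sapiens), with stated times of 10 min and 60 min (a lower number here means a stronger inhibitor, a higher number a weaker inhibitor), the only full number recorded here. Compound 1 `O=C1NC(=O)c2c(NCc3ccccc3[N+](=O)[O-])cccc21` reaches only the limit of > 100000 nM in this assay, a limit rather than a number (the limit of > 100000 nM in this assay, at which 1 of the 2 values shown sits). Compound 3 `FC(F)(F)c1cc(NCc2cccc(Br)c2)c2cn[nH]c2c1` differs from compound 2 by bromo in place of carboxy on an aromatic carbon. Among the compounds with values here, with no measured step of this kind to lean on, a modest weakening beyond the scatter is expected, a 1.8-fold higher number from compound 2 to compound 3 (0.25 log units; within the scatter). Compound 3 is therefore estimated at 3000 nM, between 700 nM and 12000 nM.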

Compound 3, half-maximal inhibitory concentration: 19100 nM
Estimate against measurement, compound 3: 6.4-fold (0.80 log units) below; the measured number lies above the stated range.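

In this assay, going by these compounds alone, this is the first step read between compounds that differ in one place, and it shows that the aromatic carbon is sensitive to its substituent: replacing carboxy with bromo gives an 11-fold higher number from compound 2 to compound 3 (1.05 log units; beyond the scatter). The carboxy group brings a hydrogen-bond donor and acceptor and bromo neither, but no measurement here ties the loss to that difference or to any other cause. As far as these compounds go, whether a primary amide, a nitrile or a hydroxyl group on this carbon would restore the number of compound 2 remains open.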